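This account rests on a few compounds, and the source may have more. Where it says the series, first, only, none or still open, it means among the compounds named here.

Among the measured compounds shown here, compound 2 `Cc1cc(Nc2cc(-c3ccccc3)[nH]n2)n2nc(SCCCc3ccccc3)nc2n1` gives 6510 nM in a functional assay on MGC-803 cells (Homo sapiens) for inhibition, read by MTT assay, with a stated time of 72 h (a lower number here means a stronger inhibitor, a higher number a weaker inhibitor), the highest of the two numbers in hand; its nearest neighbour, compound 1 `Cc1cc(Nc2cc(-c3ccccc3)[nH]n2)n2nc(SCc3ccc([N+](=O)[O-])cc3)nc2n1`, gives 4250 nM, and the single measured step, a 1.5-fold higher number from compound 1 to compound 2 (0.19 log units; within the scatter), lies within the scatter. Compound 3 `Cc1cc(Nc2cc(-c3ccccc3)[nH]n2)n2ncnc2n1` is not yet measured. It differs from compound 2 in one place: hydrogen in place of (3-phenylpropyl)sulfanyl on an aromatic carbon. For the measured compounds named here, the step from compound 1 to compound 2 exchanged only the group on a saturated chain carbon bound to a sulfur and left the numbers within the scatter, so it bears on this change only loosely; no measured pair shows what removing the whole (3-phenylpropyl)sulfanyl group does. The expectation is therefore uncertain, with a move toward a higher number in this assay thought somewhat more likely than a lower one, an estimated step of a 1.8-fold higher number from compound 2 to compound 3 (0.27 log units; within the scatter). Compound 3 is expected to give about 12000 nM in this assay, within a range from 3500 nM to 45000 nM.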

Compound 3, half-maximal inhibitory concentration: 21700 nM
Estimate against measurement, compound 3: 1.8-fold (0.26 log units) below; the range from low to high includes it.
By their numbers in this assay, from the lowest: compounds 1 and 2 (each within the scatter of the next); then compound 3.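

Taking the whole sulfanyl substituent off this aromatic carbon gives the first steps beyond the scatter in this assay, with a 3.3-fold higher number from compound 2 to compound 3 (0.52 log units; beyond the scatter) and a 5.1-fold higher number from compound 1 to compound 3 (0.71 log units; beyond the scatter), both modest. So while the exchange further out on the chain left compound 1 and compound 2 within the scatter of each other, the presence of either substituent at this position goes with a lower number than hydrogen, even though the two substituents end in different aryl groups. Nothing measured here explains this difference.

Since both substituents carry sulfur and a phenyl ring together, the compounds shown do not separate what each contributes. Open too, from the compounds shown here alone, is whether a small methylsulfanyl group, an amine or an ether oxygen in place of the sulfur would keep the lower numbers.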